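A 1,4-diazepan-1-yl swap on a sulfonyl sulfur

A few compounds are considered here, and "the series" means these few. Any claim that something is new, unique, unknown or untested is made for them only; others in the source may bear on it.

Measured so far in an ADME assay on microsomes from liver (Homo sapiens) for pharmacokinetics, read by LC-MS, with a stated time of 60 min, tested at 1 uM; on this read-out higher numbers stand for fast clearance and lower numbers for slow clearance
- compound 1 `O=C(NCc1cnccn1)Nc1ccc(S(=O)(=O)c2ccccc2)cc1` (5 mL/min/kg)
- compound 2 `C[C@@H]1CN(S(=O)(=O)c2ccc(NC(=O)NCc3cccnc3)cc2)C[C@H](C)O1` (17 mL/min/kg)

Compound 2 holds the higher of the two numbers (17 mL/min/kg), and its gap to compound 1 (5 mL/min/kg) lies beyond the scatter. Compound 3 (`O=C(NCc1cccnc1)Nc1ccc(S(=O)(=O)N2CCCNCC2)cc1`) has not yet been measured. It differs from compound 2 by a single change (1,4-diazepan-1-yl in place of 2,6-dimethylmorpholin-4-yl on a sulfonyl sulfur), with 1,4-diazepan-1-yl in place of 2,6-dimethylmorpholin-4-yl on a sulfonyl sulfur. Among the measured compounds shown here, no measured pair isolates this change, so the data offer only weak guidance. For the measured compounds named here, the one lower reference is compound 1 (5 mL/min/kg), which differs from compound 2 in more than one place. A modest downward step in this assay is expected (a 2.1-fold lower number from compound 2 to compound 3 (0.33 log units; beyond the scatter)). For compound 3 the expected value is 8 mL/min/kg (estimated range 3 mL/min/kg to 20 mL/min/kg).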

Compound 3, clearance: 6 mL/min/kg
Compound 3: the middle estimate sits 1.3-fold (0.12 log units) above what was measured, and the stated range covers the measured number.
By their numbers in this assay, from the lowest: compounds 1 and 3 (each within the scatter of the next); then compound 2.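

In this assay, putting 1,4-diazepan-1-yl in place of 2,6-dimethylmorpholin-4-yl on a sulfonyl sulfur gives a 2.8-fold lower number from compound 2 to compound 3 (0.45 log units; beyond the scatter), a modest step. Among the compounds shown here, this is the first pair to isolate a single change, and it shows that the clearance read-out responds to the group at this position while the rest of the molecule stays fixed. Nothing measured here explains why the number falls.

The change alters ring size, ring hetero atoms, the hydrogen-bond donor count and the two defined stereocentres all at once, so the compounds shown cannot say which of these differences carries the step. Plain morpholin-4-yl and piperazin-1-yl on the same sulfonyl sulfur remain open, and either could help separate those differences.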